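Changing the Outer Ring of a Glucosylceramide Synthase Inhibitor

A few compounds are considered here, and "the series" means these few. Any claim that something is new, unique, unknown or untested is made for them only; others in the source may bear on it.

Three compounds share the same core and differ only in the outer aromatic ring. In an assay on isolated protein for inhibition of ceramide glucosyltransferase (Homo sapiens) (on this read-out lower numbers stand for stronger inhibition and higher numbers for weaker inhibition), compound 1 `COc1cccc(-c2ccc(COCCCCCN3C[C@H](O)[C@@H](O)[C@H](O)[C@H]3CO)cc2)c1` gives 150 nM, and compound 2 `N#Cc1ccc(-c2ccc(COCCCCCN3C[C@H](O)[C@@H](O)[C@H](O)[C@H]3CO)cc2)cc1` gives 150 nM; between these two there is no change at the digits printed from compound 1 to compound 2 (within the scatter). In this assay compound 3 `OC[C@@H]1[C@@H](O)[C@H](O)[C@@H](O)CN1CCCCCOCc1ccc(-c2ccc3c(c2)OCCO3)cc1` gives 40 nM, the lowest of the three numbers, with a 3.8-fold lower number from compound 1 to compound 3 (0.57 log units; beyond the scatter) and a 3.8-fold lower number from compound 2 to compound 3 (0.57 log units; beyond the scatter).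

Compound 4 `OC[C@@H]1[C@@H](O)[C@H](O)[C@@H](O)CN1CCCCCOCc1ccc(-c2ccnc(F)c2)cc1` differs from compound 3 by 2-fluoropyridin-4-yl in place of 2,3-dihydro-1,4-benzodioxin-6-yl on an aromatic carbon. Within the data shown here, no measured step involves a 2-fluoropyridin-4-yl group, so the expectation rests on the two steps that lead to compound 3: both a 3.8-fold lower number from compound 1 to compound 3 (0.57 log units; beyond the scatter) and a 3.8-fold lower number from compound 2 to compound 3 (0.57 log units; beyond the scatter) show that the two other outer rings gave higher numbers than the 2,3-dihydro-1,4-benzodioxin-6-yl group. Leaving that group is therefore expected to raise the number again, roughly a 3.0-fold higher number from compound 3 to compound 4 (0.48 log units; beyond the scatter), back toward the values of compounds 1 and 2. Compound 4 is estimated at 120 nM, with a range from 40 nM to 350 nM in this assay.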

Compound 4, half-maximal inhibitory concentration: 150 nM
For compound 4 the middle estimate is 1.3-fold (0.10 log units) below the measured one; the measured number falls inside the stated range.
By their numbers in this assay, from the lowest: compound 3; then compounds 1, 2 and 4 (each within the scatter of the next).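

Compound 4 shows that the lower number of compound 3 does not carry over to this third outer ring: at this position, on an aromatic carbon para to a large group, swapping the 2,3-dihydro-1,4-benzodioxin-6-yl group for 2-fluoropyridin-4-yl in this assay gives a clear loss (a 3.8-fold higher number from compound 3 to compound 4 (0.57 log units; beyond the scatter)). The new ring cannot be told apart from the other two (no change at the digits printed from compound 2 to compound 4 (within the scatter); no change at the digits printed from compound 1 to compound 4 (within the scatter)), so among these four compounds only the 2,3-dihydro-1,4-benzodioxin-6-yl group stands apart. Nothing available here explains why that group differs.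

The compounds shown leave open whether the lower number needs the whole of that group or only part of it. An unsubstituted phenyl ring or a 3,4-dimethoxyphenyl ring at this position would help to separate the two.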